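From 4-fluorobenzyl to 4-bromobenzyl

A few compounds are considered here, and "the series" means these few. Any claim that something is new, unique, unknown or untested is made for them only; others in the source may bear on it.

Compound 1 `Cc1cc(Nc2nc(NCc3ccccc3Cl)nc3[nH]ncc23)n[nH]1` gives 4210 nM
Compound 2 `Cc1cc(Nc2nc(NCc3ccccc3Br)nc3[nH]ncc23)n[nH]1` gives 3990 nM
Compound 3 `Cc1cc(Nc2nc(NCc3ccc(F)cc3)nc3[nH]ncc23)n[nH]1` gives 8410 nM

In a functional assay on MDA-MB-231 cells (Homo sapiens) for inhibition, read by MTT assay, with a stated time of 5 days (a lower number here means a stronger inhibitor, a higher number a weaker inhibitor), compound 3 gives 8410 nM, at the upper end of the three values, with a 2.0-fold higher number from compound 1 to compound 3 (0.30 log units; within the scatter) and a 2.1-fold higher number from compound 2 to compound 3 (0.32 log units; beyond the scatter). Compound 4 `Cc1cc(Nc2nc(NCc3ccc(Br)cc3)nc3[nH]ncc23)n[nH]1` carries bromo in place of fluoro on an aromatic carbon, para to a large group (bromo in place of fluoro on an aromatic carbon). Among the compounds with values here, no measured pair makes this exact change. The nearest halogen exchange is a 1.1-fold lower number from compound 1 to compound 2 (0.02 log units; within the scatter). The two steps into compound 3 also move the halogen, so they bear on it only loosely. Only a small shift towards a lower number is therefore expected, and the estimate is a 1.4-fold lower number from compound 3 to compound 4 (0.15 log units; within the scatter). For compound 4 the expected value is 6000 nM, with an estimated range of 3000 nM to 11000 nM.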

Compound 4, half-maximal inhibitory concentration: 1860 nM
Compound 4: the middle estimate sits 3.2-fold (0.51 log units) above what was measured; measured number outside the range, below it.
By their numbers in this assay, from the lowest: compound 4; then compounds 2, 1 and 3 (each within the scatter of the next, the first and the last beyond it).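

In this assay, within the data shown here, the exchange of fluoro for bromo at this position is a real change: a 4.5-fold lower number from compound 3 to compound 4 (0.66 log units; beyond the scatter), whereas the only earlier halogen exchange stayed within the scatter, with a 1.1-fold lower number from compound 1 to compound 2 (0.02 log units; within the scatter). The 4-bromobenzyl group also separates compound 4 from the two earlier compounds carrying bromo or chloro, with a 2.1-fold lower number from compound 2 to compound 4 (0.33 log units; beyond the scatter) and a 2.3-fold lower number from compound 1 to compound 4 (0.35 log units; beyond the scatter), which gives it the lowest number of the four. Nothing available explains this step.

On these data alone, whether chloro or methyl at the same place would fall nearer compound 3 or compound 4 remains open. So does the effect of an amine or a carboxylic acid there.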